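The source may report more compounds than this note shows. Statements on the series, on what has been measured and on what is new or still open speak of the compounds shown alone.

Measured in a functional assay on HCT-116 cells (Homo sapiens) for inhibition, read by MTT assay, with a stated time of 72 h; a higher number here means that more compound is tolerated, a lower number that less compound is tolerated:
Compound 1 `O=C1C=CC(O)(c2cc3ccc(F)cc3n2S(=O)(=O)c2ccccc2)C=C1`: < 10 nM
Compound 2 `COC(=O)CCc1ccc(S(=O)(=O)n2c(C3(O)C=CC(=O)C=C3)cc3ccccc32)cc1`: 20 nM

Within the data shown here, only two compounds have been tested so far, which leaves little to go on. Compound 1 gives < 10 nM, and this is a limit of the assay and not a number. Among the measured compounds shown here, compound 2 gives 20 nM, the only true number available in this assay, so it serves as the reference point here.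

The next compound to be tested is compound 3 `COC(=O)CCc1ccc(S(=O)(=O)n2c(C3(O)C=CC(=O)C=C3)cc3ccc(F)cc32)cc1`. It is compound 2 with one small edit, fluoro in place of hydrogen on an aromatic carbon.

For the measured compounds named here, no pair of measured compounds differs in one place alone, so no measured step shows what a change of this kind does. With nothing to suggest a large shift, a step no larger than the usual scatter is expected, with no firm direction. The expected step is a 1.3-fold lower number from compound 2 to compound 3 (0.12 log units; within the scatter), which is estimated to stay within that scatter. For compound 3 the estimated value is 15 nM, with an expected range from 5 nM to 40 nM.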

Compound 3, concentration lethal to 50% of the cells: 720 nM
Estimate against measurement, compound 3: 48-fold (1.68 log units) below, and the stated range ends below it.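

In this assay, fluoro in place of hydrogen on an aromatic carbon proves to be no minor edit when the 2-(methoxycarbonyl)ethyl chain is present: the change gives a 36-fold higher number from compound 2 to compound 3 (1.56 log units; beyond the scatter), so the cells tolerate far more of the fluoro compound. Fluoro alone does not account for this, since adding the chain to the fluoro-bearing core gives an at least 72-fold higher number from compound 1 to compound 3 (1.85 log units; beyond the scatter), and the high number therefore appears only where fluoro and the chain occur together. That second step has only a lower bound, as compound 1 stands at a limit of the assay and not at a number: the limit of < 10 nM in this assay, at which 1 of the 3 values shown sits.

The compounds shown leave open what fluoro does at this position on a core that lacks the chain, and nothing here explains why the two groups behave this way together. Chloro in place of the fluoro, or a carboxylic acid in place of the methoxycarbonyl end of the chain, would show whether the large step belongs to these exact groups or extends to their neighbours.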